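This account rests on a few compounds, and the source may have more. Where it says the series, first, only, none or still open, it means among the compounds named here.

In a functional assay (blood) for inhibition, with Homo sapiens as the target (on this read-out lower numbers stand for stronger inhibition and higher numbers for weaker inhibition), compound 1 `C/C(=N\OCCSc1nnnn1C)c1ccc(Sc2cc(F)cc(C3CCOCC3)c2)cc1` gives 120 nM. Going by the values given here, of the three numbers measured so far this is the second highest. Compound 3 `COC1(c2csc(Sc3ccc4c(c3)OCC/C4=N\OCC#N)c2)CCOCC1` gives 60 nM in this assay, a value that lies within the scatter of that of compound 1, so no order between the two can be read. Compound 2 `C/C(=N\O)c1cccc(Sc2cc(F)cc(C3CCOCC3)c2)c1` gives 2910 nM in this assay, a number far beyond the scatter from that of compound 1. Compound 4 `C/C(=N\OCC#N)c1ccc(Sc2cc(F)cc(C3CCOCC3)c2)cc1` has not yet been measured in this assay. It differs from compound 1 at one place: cyano in place of ((1-methyl-1H-tetrazol-5-yl)sulfanyl)methyl on a saturated chain carbon bound to an oxygen. Among the compounds with values here, the cyanomethoxy group that results is also the one carried on the core of compound 3, though no pair of measured compounds isolates this change, so only the values of compound 1 and compound 3 offer guidance. Compound 4 is expected to land near compound 1, and the step this expectation means, a 1.2-fold lower number from compound 1 to compound 4 (0.08 log units; within the scatter), is expected to be small and not beyond the scatter. The estimate for compound 4 is 100 nM, with a range from 35 nM to 300 nM.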

Compound 4, half-maximal inhibitory concentration: 20 nM
For compound 4 the middle estimate is 5.0-fold (0.70 log units) above the measured one, and the stated range ends above it.
By their numbers in this assay, from the lowest: compound 4; then compounds 3 and 1 (each within the scatter of the next); then compound 2.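

In this assay, cyano in place of ((1-methyl-1H-tetrazol-5-yl)sulfanyl)methyl on a saturated chain carbon bound to an oxygen gives a 6.0-fold lower number from compound 1 to compound 4 (0.78 log units; beyond the scatter) and so lies beyond the scatter. This is the first single change shown at this place, and it shows that the number responds to what the place carries. The tetrazole ring is not needed there for a low number, since cyano, with 2 heavy atoms against 8 and no ring, gives the lower value, and nothing measured here accounts for the step.

The compounds shown leave open whether the nitrile itself matters, as a plain methyl, a hydroxyl or a longer 2-cyanoethyl chain at this place could tell. They also leave open whether the step would carry over to a different core.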